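Swapping dimethylphenyl for dichlorophenyl on a ring nitrogen

A few compounds are considered here, and "the series" means these few. Any claim that something is new, unique, unknown or untested is made for them only; others in the source may bear on it.

Compound 1 `Cc1nc(-c2ccccc2)c(C(=O)N2CCN(c3cccc(C)c3C)CC2)o1` was run in an ADME assay on microsomes from liver (Mus musculus) for metabolic stability, read by LC-MS, with a stated time of 1 h, tested at 5 uM (a lower number here means that less of the compound is left, a higher number that more of the compound is left), and gives 83.6%. Compound 2 `CCC[C@H](Nc1nc(-c2ccc(NC(=O)NCC)c(OC)c2)ncc1C)c1cccnc1`, built on a different core, gives 87.5% in this assay, a number within the scatter of that of compound 1, so the two stand level. Compound 3 `Cc1nc(-c2ccccc2)c(C(=O)N2CCN(c3cc(Cl)cc(Cl)c3)CC2)o1` has not been measured. It differs from compound 1 in one place: 3,5-dichlorophenyl in place of 2,3-dimethylphenyl on an amine nitrogen in a ring. Going by the values given here, no step between measured compounds covers this kind of change, so its size in this assay cannot be read from the data. The step of a number 2.4 percentage points higher from compound 1 to compound 3 (within the scatter) is expected to stay within the scatter, in neither direction. Compound 3 is estimated at 86%, between 70% and 97%.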

Compound 3, percent of the compound remaining: 43.4%
The estimate for compound 3 lay 42.6 percentage points above the measured number; measured number below the stated range.
By their numbers in this assay, from the lowest: compound 3; then compounds 1 and 2 (each within the scatter of the next).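

With 3,5-dichlorophenyl in place of 2,3-dimethylphenyl on the amine nitrogen in the ring, this assay shows a number 40.2 percentage points lower from compound 1 to compound 3 (beyond the scatter). Going by these compounds alone, this is the first sign that the aryl group at this position matters in this assay, even though the heavy-atom count and the counted hydrogen-bond donors and acceptors stay the same. No measurement at hand explains the step. Still open, going by these compounds, is whether the chlorine atoms or their placement on the ring accounts for it. A 3,5-dimethylphenyl or 2,3-dichlorophenyl group on the same nitrogen would separate the two.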